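The source may hold more compounds than are shown below. What is called first, only, known or untested is meant among the compounds shown, and "the series" means these compounds.

Measured so far:
Compound 1 `O=C(NO)c1ccc(/C=C/c2ccnc(-c3cccc(O)c3)c2)cc1`: 1610 nM
Compound 2 `Cc1ccc(-c2cc(/C=C/c3ccc(C(=O)NO)cc3)ccn2)cc1`: 2390 nM
Compound 3 `COc1ccc(-c2cc(/C=C/c3ccc(C(=O)NO)cc3)ccn2)cc1`: 3560 nM

All three values come from a functional assay on HCT-116 cells (Homo sapiens) for antiproliferative activity, read by CellTiter-Glo, with a stated time of 72 h; on this read-out higher numbers stand for weaker inhibition and lower numbers for stronger inhibition. Compound 3 is clearly separated only from compound 1: a 2.2-fold higher number from compound 1 to compound 3 (0.34 log units; beyond the scatter), whereas a 1.5-fold higher number from compound 2 to compound 3 (0.17 log units; within the scatter). The remaining step, a 1.5-fold higher number from compound 1 to compound 2 (0.17 log units; within the scatter), also leaves the two numbers indistinguishable.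

Next in the series is compound 4 `O=C(NO)c1ccc(/C=C/c2ccnc(Br)c2)cc1`, not yet measured in this assay. The change is bromo in place of 4-methoxyphenyl on an aromatic carbon, next to the ring nitrogen: bromo in place of 4-methoxyphenyl on an aromatic carbon.

The measured steps bear on this only indirectly. Each swaps one substituted phenyl for another or alters the substituent on that phenyl, and none removes the phenyl itself. They show that such edits move the number little, the largest being the modest step to compound 3 noted above. For the measured compounds named here, the data contain no compound without this phenyl, so they give no direction for its loss. No step beyond the scatter is therefore expected, although the uncertainty is wide.

The estimated step is a 1.2-fold lower number from compound 3 to compound 4 (0.07 log units; within the scatter). For compound 4 the expected value is 3000 nM, with an estimated range of 800 nM to 11000 nM.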

Compound 4, half-maximal inhibitory concentration: > 10000 nM
Compound 4: a limit, no number; the forecaster's own chance of this, stated with the estimate: 10%; middle value at least 3.3-fold (0.52 log units) away from the limit.
By their numbers in this assay, from the lowest: compounds 1, 2 and 3 (each within the scatter of the next, the first and the last beyond it). At a limit, above all of these: compound 4.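

In this assay compound 4 gives a limit of the assay and not a number: the limit of > 10000 nM in this assay, at which 1 of the 4 values shown sits.

The earlier compounds shown here exchanged one substituted phenyl for another or altered the substituent on that phenyl, whereas replacing the whole phenyl with bromo on this aromatic carbon, next to the ring nitrogen, produces a step beyond the scatter against each of them: an at least 2.8-fold higher number from compound 3 to compound 4 (0.44 log units; beyond the scatter), an at least 4.1-fold higher number from compound 2 to compound 4 (0.62 log units; beyond the scatter) and an at least 6.2-fold higher number from compound 1 to compound 4 (0.79 log units; beyond the scatter). Among the compounds shown, all three that carry a substituted phenyl here have lower numbers than the bromo compound, with none going against this, so this position accepts changes on the phenyl far more readily than replacement of the phenyl by bromo.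

For the compounds shown here, compound 4 is the only compound without a phenyl at this position, so the absence of the ring and the presence of bromine cannot be told apart, and the full size of the steps remains unknown. As far as these compounds go, it also remains open whether a hydrogen, an amine, a morpholine or an unsubstituted phenyl at this position would fall with the substituted phenyl compounds or with compound 4.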